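The source may hold more compounds than are shown below. What is called first, only, known or untested is meant among the compounds shown, and "the series" means these compounds.

Measured so far in a functional assay on BGC-823 cells (Homo sapiens) for antiproliferative activity, read by MTT assay, with a stated time of 48 h; on this read-out lower numbers stand for stronger inhibition and higher numbers for weaker inhibition:

- compound 1 `Fc1ccccc1CSc1nnc(-c2cnccn2)o1`: 18200 nM
- compound 2 `Clc1ccccc1CSc1nnc(-c2cnccn2)o1`: 27700 nM
- compound 3 `Brc1ccccc1CSc1nnc(-c2cnccn2)n1-c1ccccc1`: 36200 nM

These three values all lie within the usual scatter of one another, so compound 3, at 36200 nM, cannot be ranked apart from the other two. Compound 4 `Brc1ccc(CSc2nnc(-c3cnccn3)n2-c2ccccc2)cc1` has not been measured yet. It has the same atoms as compound 3, joined differently: 4-bromophenyl in place of 2-bromophenyl on a saturated chain carbon bound to a sulfur. Here 4-bromophenyl stands in place of 2-bromophenyl on a saturated chain carbon bound to a sulfur.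

Going by the values given here, only one measured step offers any guide, and it is a different kind of change: chloro in place of fluoro on an aromatic carbon, a 1.5-fold higher number from compound 1 to compound 2 (0.18 log units; within the scatter). Among the compounds with values here, no measured pair shows a change like the one in compound 4, so the evidence is thin. The data therefore give no reason to expect a step beyond the scatter in this assay, in either direction. The expected change is a 1.1-fold lower number from compound 3 to compound 4 (0.05 log units; within the scatter). For compound 4 the estimated value is 32000 nM, with an expected range from 14000 nM to 70000 nM.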

Compound 4, half-maximal inhibitory concentration: 19800 nM
For compound 4 the middle estimate is 1.6-fold (0.21 log units) above the measured one, and the stated range covers the measured number.
By their numbers in this assay, from the lowest: compounds 1, 4, 2 and 3 (each within the scatter of the next).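

In this assay, 4-bromophenyl in place of 2-bromophenyl on a saturated chain carbon bound to a sulfur gives a 1.8-fold lower number from compound 3 to compound 4 (0.26 log units; within the scatter) for this pair. This is the first pair shown in which only the placing of the bromine differs, with the atoms themselves unchanged, and that difference does not separate compound 3 and compound 4 beyond the usual scatter of repeated measurements. No measured data bear on what lies behind this step.

As far as these compounds go, it remains open whether 2-fluorobenzyl and 4-fluorobenzyl, or 2-chlorobenzyl and 4-chlorobenzyl, would behave the same way, on this core or on the core of compound 1. From the compounds shown here alone, it also remains open what a benzyl group carrying an amine or a carboxylic acid in place of the bromine would give.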